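Shrinking the Group on One Oxygen to Oxetan-3-yl

The source may hold more compounds than are shown below. What is called first, only, known or untested is meant among the compounds shown, and "the series" means these compounds.

Compound 1 (`CC(C)(C)C#Cc1cc(N(C(=O)[C@H]2CC[C@H](C)CC2)[C@H]2CC[C@H](Oc3ccc4nccn4n3)CC2)c(C(=O)O)s1`) is the starting point. In a physicochemical assay for lipophilicity (a higher number here means a more lipophilic compound, a lower number a more polar compound), compound 1 gives 2.4 as its reading, and compound 2 (`CC(C)(C)C#Cc1cc(N(C(=O)[C@H]2CC[C@H](C)CC2)[C@H]2CC[C@](O)(CO[C@H]3CCOC3)CC2)c(C(=O)O)s1`) gives 2.4 on the same measure, so the two stand level within the usual scatter.

Compound 3 (`CC(C)(C)C#Cc1cc(N(C(=O)[C@H]2CC[C@H](C)CC2)[C@H]2CC[C@H](OC3COC3)CC2)c(C(=O)O)s1`) has not been measured yet. It keeps the core of compound 1 but changes one group, on an oxygen on a saturated carbon: a group of 4 heavy atoms (3 carbon, 1 oxygen; one four-membered non-aromatic ring with 1 hetero atom) in place of a group of 9 heavy atoms (6 carbon, 3 nitrogen; one five-membered aromatic ring with 2 hetero atoms, one six-membered aromatic ring with 2 hetero atoms), on an oxygen on a saturated carbon. The group that leaves has two aromatic rings, while oxetan-3-yl has a single four-membered non-aromatic ring.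

For the measured compounds named here, no measured pair shows this swap on its own, so the evidence is thin. Going by the values given here, the only guide is that, although built differently from compound 1, compound 2 still reads 2.4 in this assay. On that basis, the expected change is small, a number 0.10 log units lower from compound 1 to compound 3 (within the scatter), and no shift beyond the scatter is expected in either direction. For compound 3 the estimated value is 2.3, with an expected range from 1.8 to 2.8.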

Compound 3, distribution coefficient: 2.6
Beside the measured number, compound 3's estimate is 0.30 log units below it, within the range that was stated.
By their numbers in this assay, from the lowest: compounds 1, 2 and 3 (each within the scatter of the next).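

Putting oxetan-3-yl in place of the group with two aromatic rings, on an oxygen on a saturated carbon, gives a number 0.20 log units higher from compound 1 to compound 3 (within the scatter) in this assay and is the first step shown here that differs in one place. It shows that, at this position, the two groups give readings that stand level, although oxetan-3-yl has 4 heavy atoms against the 9 of the group that leaves, one hydrogen-bond acceptor against three, and no aromatic ring against two, so these differences taken together leave no reading beyond the scatter in this pair. No supporting measurement is available to explain why the two readings stand level.

This single pair cannot separate the effects of ring size, aromatic rings and nitrogen atoms, since all of them differ at once between compound 1 and compound 3. Going by these compounds, whether the readings would stay level with a group of another kind on this oxygen, such as an amine, a carboxylic acid or a longer chain, remains open, as does whether the same swap would read alike on a different core.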